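Swapping an aryl amide for a pyrazinyl amide

The source may hold more compounds than are shown below. What is called first, only, known or untested is meant among the compounds shown, and "the series" means these compounds.

Of the compounds shown here, two built on a shared core have been measured in an in vitro assay on FRT cells with Cystic fibrosis transmembrane conductance regulator variant F508del (Homo sapiens) as the target, read by fluorescence, with a stated time of 24 h, at 37 degrees C, in the presence of a further agent that is not named here; a higher number here means that more compound is needed for the effect, a lower number that less compound is needed. Compound 1 `Cc1cc(C)c2cc(C#N)c(NCCNC(=O)c3ccncc3)nc2c1`, which carries a pyridin-4-yl group on its amide carbonyl carbon, gives 7300 nM in this assay. Going by the values given here, compound 2 `COc1ccc(C(=O)NCCNc2nc3cc(C)cc(C)c3cc2C#N)cc1OC`, with a 3,4-dimethoxyphenyl group in that position, gives 1500 nM, and the single step between them, a 4.9-fold lower number from compound 1 to compound 2 (0.69 log units; beyond the scatter), is modest but clear. Within these two numbers compound 2 stands at the lower of the pair, so the dimethoxyphenyl amide needs less compound for the effect than the pyridyl amide.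

Compound 3 `Cc1cc(C)c2cc(C#N)c(NCCNC(=O)c3cnccn3)nc2c1` is the next variation, again changing only the group on the carbonyl carbon: pyrazin-2-yl in place of 3,4-dimethoxyphenyl on a carbonyl carbon. Among the compounds with values here, the only measured step that bears on this change is the one from the pyridin-4-yl amide to the dimethoxyphenyl amide, and the change to compound 3 runs the other way, back toward a small six-membered ring with ring nitrogens. The expectation for compound 3 is therefore a higher number than compound 2, and the step is expected to be about a 4.0-fold higher number from compound 2 to compound 3 (0.60 log units; beyond the scatter), close in size to the measured step in reverse. The estimate for compound 3 in this assay is 6000 nM, with a range from 2500 nM to 15000 nM.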

Compound 3, half-maximal effective concentration: 6700 nM
Compound 3: middle estimate off by 1.1-fold (0.05 log units), on the low side, within the range that was stated.
By their numbers in this assay, from the lowest: compound 2; then compounds 3 and 1 (each within the scatter of the next).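

The new step in this assay (a 4.5-fold higher number from compound 2 to compound 3 (0.65 log units; beyond the scatter)) shows that the gain seen with the 3,4-dimethoxyphenyl group does not carry over to the pyrazin-2-yl group on this carbonyl carbon, and the size of the step is modest but beyond the scatter. The second new step (a 1.1-fold lower number from compound 1 to compound 3 (0.04 log units; within the scatter)) lies within the scatter, so pyrazin-2-yl and pyridin-4-yl cannot be told apart here, and among these three amides only compound 2 stands clear of the other two, a division that rests on a single carbon-only ring carrying two methoxy groups against two rings with ring nitrogens. Nothing available here accounts for this separation.

The change from compound 2 to compound 3 alters the ring atoms, the substituents and the heavy-atom count all at once, so these three compounds cannot say which of those differences goes with the shift in the number. An unsubstituted phenyl ring, or a phenyl ring with a single methoxy group, on the same carbonyl carbon would be needed to separate the contribution of the methoxy groups from that of the ring nitrogens.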